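The compounds below may be only part of what the source reports. "The series", "measured", "known", "first", "only" and "open" are said of these compounds alone.

Measured so far:
Compound 1, `CN(C)CCN(CCN(C)C)c1cccc(C(=O)N2CCc3ccc(OS(N)(=O)=O)cc3C2)c1`: 17.1%
Compound 2, `CCN(Cc1cccc(Br)c1)c1ccc(C(=O)N2CCc3ccc(OS(N)(=O)=O)cc3C2)cc1`: 97.2%
Compound 3, `CCN(Cc1ccccn1)c1ccc(C(=O)N2CCc3ccc(OS(N)(=O)=O)cc3C2)cc1`: 87.7%

All three share one core and differ only in the group attached to the amide. In an assay on HEK293 cells for inhibition of Steryl-sulfatase (Homo sapiens), tested at 1 uM (a lower number here means a weaker effect, a higher number a stronger effect of the compound at the concentration tested), compound 3 gives 87.7%, the second highest of the three numbers. Its nearest neighbour is compound 2; the step of a number 9.5 percentage points lower from compound 2 to compound 3 (within the scatter) lies within the usual scatter, so the two cannot be told apart. Its furthest neighbour is compound 1, whose reading of 17.1% is far lower, well beyond the scatter.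

The next compound, compound 4, `CCN(Cc1ccc(F)cc1)c1ccc(C(=O)N2CCc3ccc(OS(N)(=O)=O)cc3C2)cc1`, has not yet been measured. It differs from compound 3 in one place: 4-fluorophenyl in place of pyridin-2-yl on a saturated chain carbon bound to a nitrogen on an aromatic ring.

Going by the values given here, only one measured step bears on this change, namely the swap of one aromatic ring for another on that same saturated chain carbon, which gave a number 9.5 percentage points lower from compound 2 to compound 3 (within the scatter). That swap moved the number by less than the scatter. A further swap of the same kind, again exchanging one six-membered aromatic ring for another, is therefore expected to leave the reading close to where compound 3 stands. For compound 4 the expected step is a number 2.3 percentage points higher from compound 3 to compound 4 (within the scatter). Compound 4 is thus estimated at about 90%, likely between 76% and 99%.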

Compound 4, a percentage reported as inhibition, at one concentration (the size of the read-out at that concentration, not a potency): 91.2%
Compound 4: middle estimate off by 1.2 percentage points, on the low side; the measured number falls inside the stated range.
By their numbers in this assay, from the lowest: compound 1; then compounds 3, 4 and 2 (each within the scatter of the next).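

At this position, on a saturated chain carbon bound to a nitrogen on an aromatic ring, 4-fluorophenyl reads like both earlier rings in this assay: the swap for pyridin-2-yl (a number 3.5 percentage points higher from compound 3 to compound 4 (within the scatter)) and the swap for 3-bromophenyl (a number 6 percentage points lower from compound 2 to compound 4 (within the scatter)) both stay within the usual scatter. With this third ring, the three six-membered aromatic rings shown, one with a ring nitrogen, one with a fluorine and one with a bromine, cannot be told apart here, so this read-out shows no sign that either the hetero atom or the choice of halogen matters. No measurement is available that explains why these rings read alike.

The compounds shown leave open whether the reading would hold with something other than an aromatic ring on this chain carbon, such as a cyclohexyl ring, a longer alkyl chain, a carboxylic acid or an amine. They also leave open whether these three compounds differ in potency, since a reading at a single concentration gives the size of the effect at that concentration and not a potency.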